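From 3-methylphenyl to 4-methylphenyl on a sulfonyl chain

The source may report more compounds than this note shows. Statements on the series, on what has been measured and on what is new or still open speak of the compounds shown alone.

In an ADME assay on MT4 cells (Homo sapiens) for cytotoxicity, read by MTT assay, with a stated time of 5 days (on this read-out higher numbers stand for lower toxicity in this test and lower numbers for higher toxicity in this test), compound 1 `O=c1[nH]c2ccc(Cl)cc2n1S(=O)(=O)CCc1ccc(Cl)cc1` gives 91000 nM, compound 2 `Cc1ccccc1CCS(=O)(=O)n1c(=O)[nH]c2ccc(Cl)cc21` gives 32000 nM and compound 3 `Cc1cccc(CCS(=O)(=O)n2c(=O)[nH]c3ccc(Cl)cc32)c1` gives 31000 nM. Compound 3 shares the low end of this small range with compound 2, and the numbers show a 1.0-fold lower number from compound 2 to compound 3 (0.01 log units; within the scatter). Both lie clearly under compound 1, with a 2.8-fold lower number from compound 1 to compound 2 (0.45 log units; beyond the scatter) and a 2.9-fold lower number from compound 1 to compound 3 (0.47 log units; beyond the scatter).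

Compound 4 `Cc1ccc(CCS(=O)(=O)n2c(=O)[nH]c3ccc(Cl)cc32)cc1` has not yet been measured. It carries 4-methylphenyl in place of 3-methylphenyl on a saturated chain carbon, two bonds along the chain from a sulfonyl sulfur.

Going by the values given here, the nearest precedent is the exchange of 2-methylphenyl for 3-methylphenyl, which produced no step beyond the scatter. A further exchange of the same kind is therefore not expected to produce a large one. Among the compounds with values here, compound 1, which has 4-chlorophenyl at this place and stands at 91000 nM, leaves room for a small rise, but it is the only compound with a group named at the 4 position, and its chlorine differs from a methyl. In this assay, the expected outcome is a 1.3-fold higher number from compound 3 to compound 4 (0.11 log units; within the scatter), which would stay within the scatter. Compound 4 is estimated at 40000 nM, with an expected range from 20000 nM to 85000 nM.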

Compound 4, half-maximal cytotoxic concentration: 161000 nM
Beside the measured number, compound 4's estimate is 4.0-fold (0.60 log units) below it; measured number outside the range, above it.
By their numbers in this assay, from the lowest: compounds 3 and 2 (each within the scatter of the next); then compounds 1 and 4 (each within the scatter of the next).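

Where the methyl sits on the phenyl ring matters in this assay, even though the two earlier methylphenyl compounds could not be told apart: there is a 5.2-fold higher number from compound 3 to compound 4 (0.72 log units; beyond the scatter) and a 5.0-fold higher number from compound 2 to compound 4 (0.70 log units; beyond the scatter), so the 4-methylphenyl group separates from both the 3-methylphenyl and 2-methylphenyl groups on the saturated chain carbon. The exchange of chloro for methyl on the aromatic carbon, by contrast, leaves a 1.8-fold higher number from compound 1 to compound 4 (0.25 log units; within the scatter), which means that the 4-chlorophenyl and 4-methylphenyl compounds are not distinguished and that the earlier gap under compound 1 no longer looks specific to its chlorine, although this rests on only these two groups with a substituent at the 4 position. Nothing available here accounts for why the 4-methylphenyl group parts from the other two methylphenyl groups.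

On these data alone, it remains open whether 2-chlorophenyl and 3-chlorophenyl would fall with their methyl counterparts, and whether other groups such as 4-methoxyphenyl or 4-fluorophenyl would stay with compound 1 and compound 4. Also open, as far as these compounds go, is whether a longer chain carrying the 4-methylphenyl group would keep this separation.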